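Adding a Methyl Group: What Cytotoxicity to Expect

The source may report more compounds than this note shows. Statements on the series, on what has been measured and on what is new or still open speak of the compounds shown alone.

Three amides built on one shared core have been tested in an ADME assay on BJ cells (Homo sapiens) for cytotoxicity, with a stated time of 72 h; on this read-out lower numbers stand for an effect already at smaller amounts and higher numbers for an effect only at larger amounts of compound. Compound 1 `O=C(Nc1ccc(O)c(-c2nc3ccccc3s2)c1)c1cc([N+](=O)[O-])ccc1Cl` gives > 25000 nM, which is a limit of the assay rather than a number. Compound 2 `Cc1cc(NC(=O)c2cc([N+](=O)[O-])ccc2Cl)cc(-c2nc3ccccc3s2)c1O` gives > 25000 nM, again a limit. Compound 3 `O=C(Nc1cccc(-c2nc3ccccc3s2)c1)c1cc([N+](=O)[O-])ccc1Cl` gives > 27000 nM, also a limit. The change from compound 1 to compound 2 is methyl in place of hydrogen on an aromatic carbon, and the step that the two limits leave unreadable from compound 1 to compound 2 cannot be read because the limit of > 25000 nM in this assay, at which 2 of the 3 values shown sit, is all that either value shows. The two cores differ by hydrogen in place of hydroxy on an aromatic carbon, and the step that the two limits leave unreadable from compound 1 to compound 3 is likewise unreadable, with the limit of > 27000 nM in this assay, at which 1 of the 3 values shown sits, reached by compound 3.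

Compound 4 `Cc1c(NC(=O)c2cc([N+](=O)[O-])ccc2Cl)cccc1-c1nc2ccccc2s1` has not yet been measured. It differs from compound 3 by methyl in place of hydrogen on an aromatic carbon, the same kind of change as from compound 1 to compound 2, though there the methyl sits ortho to a hydroxy group and meta to a 1,3-benzothiazol-2-yl group, while here it sits ortho to a 1,3-benzothiazol-2-yl group. Compound 4 is expected to give about 30000 nM in this assay. This expectation rests on compound 3, whose value > 27000 nM is a limit. The step that the limit leaves unreadable from compound 3 to compound 4 is therefore expected to be small.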

Compound 4, half-maximal effective concentration: > 25000 nM
Compound 4: only a limit was reported; the forecaster's own chance of this, stated with the estimate: 85%; the middle value does not contradict the limit.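

In this assay compound 4 gives > 25000 nM, which is a limit of the assay and not a number. Compound 3 also has only a limit, > 27000 nM, so no size can be read for the step between compound 3 and compound 4. The compounds shown leave open at what amount any of them affects these cells, and whether the added methyl changes that amount.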